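The compounds below may be only part of what the source reports. "The series", "measured", "known", "first", "only" and "open" are said of these compounds alone.

Notes on the ester series built around the shared core of compound 1 `CC(C)C(=O)Oc1c(C(C)C)cc2c3c1OC(=O)[C@@]31CCCC(C)(C)[C@@H]1CC2`. Going by the values given here, in an ADME assay on HepG2 cells (Homo sapiens) for cytotoxicity, read by neutral red uptake, with a stated time of 24 h (a lower number here means a stronger inhibitor, a higher number a weaker inhibitor), compound 1 gives 112000 nM, and this is the only number the series has produced so far. Compound 2 `CCCCCCCC/C=C/CCCCCCCC(=O)Oc1c(C(C)C)cc2c3c1OC(=O)[C@@]31CCCC(C)(C)[C@@H]1CC2` is the other ester measured to date. In this assay compound 2 returns only a limit, > 1000000 nM. Thus (the limit of > 1000000 nM in this assay, at which 1 of the 2 values shown sits), which leaves compound 1 standing alone as the single measurable point. Compound 3 `CC(C)c1cc2c3c(c1OC(=O)Cc1c[nH]c4ccccc14)OC(=O)[C@@]31CCCC(C)(C)[C@@H]1CC2` has not yet been measured. It differs from compound 1 in one place: (1H-indol-3-yl)methyl in place of isopropyl on a carbonyl carbon. Among the compounds with values here, no measured pair tracks this change, so the step has to be guessed. The step from compound 1 to compound 3 is expected to be modest, about a 1.2-fold lower number from compound 1 to compound 3 (0.09 log units; within the scatter), with no direction favoured beyond the scatter. For compound 3 the expected value in this assay is 90000 nM, with a range from 25000 nM to 350000 nM.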

Compound 3, half-maximal inhibitory concentration: 251000 nM
Compound 3: the middle estimate sits 2.8-fold (0.45 log units) below what was measured; measured number inside the range.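

Going by these compounds alone, with (1H-indol-3-yl)methyl in place of isopropyl on the carbonyl carbon, this assay gives a 2.2-fold higher number from compound 1 to compound 3 (0.35 log units; beyond the scatter) and this is the first step that can be read. An ester carrying two aromatic rings and a hydrogen-bond donor at this place thus still returns a measurable number, and that number moves upward from the one seen with isopropyl. Compound 2 also changes the group on this carbon, but its result is a limit, so no step can be read from it: the limit of > 1000000 nM in this assay, at which 1 of the 3 values shown sits.

Going by these compounds, whether the upward move follows the aromatic rings, the hydrogen-bond donor or simply the larger group stays open on a single step. On these data alone, how a plain benzyl group, an amine or a carboxylic acid would read on this carbonyl carbon also remains open.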